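A few compounds are considered here, and "the series" means these few. Any claim that something is new, unique, unknown or untested is made for them only; others in the source may bear on it.

Measured compounds:
- compound 1, `CCCSc1nc(Cl)c2c(n1)N(Cc1ccccc1)C(C(=O)N1CCN(C(=O)OC(C)(C)C)CC1)N2`: 47100 nM
- compound 2, `CCCSc1nc(Cl)c2c(n1)N(Cc1ccccc1)C(C(=O)O)N2`: 49200 nM
- compound 3, `CCCSc1nc(Cl)c2c(n1)N(CC1CCCCC1)C(C(=O)N1CCN(C)CC1)N2`: 12800 nM

In a functional assay on PC-3 cells (Homo sapiens) for antiproliferative activity, read by MTT assay, with a stated time of 72 h (a lower number here means a stronger inhibitor, a higher number a weaker inhibitor), compound 2 gives 49200 nM, the highest of the three numbers. Compound 1, the amide built on the same core, gives 47100 nM in this assay, which sits within the scatter of compound 2. Compound 3, which carries a different group on the ring nitrogen and a different amide, gives 12800 nM, a lower number than compound 2 by a margin beyond the scatter.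

Compound 4, `CCCSc1nc(Cl)c2c(n1)N(Cc1ccccc1)C(C(=O)NCCNC(=O)OC(C)(C)C)N2`, is not yet measured. It differs from compound 2 by (2-((tert-butoxycarbonyl)amino)ethyl)amino in place of hydroxy on a carbonyl carbon. Among the measured compounds shown here, no pair of measured compounds differing in one place is available, so the size of this step must be judged from what compound 1 and compound 2 show: an amide of this kind next to the free acid gave numbers within the scatter of each other. The step from compound 2 to compound 4 is therefore expected to be small, a 1.2-fold lower number from compound 2 to compound 4 (0.09 log units; within the scatter), and not clearly beyond the scatter in either direction. Compound 4 is accordingly expected to give 40000 nM in this assay, with a range from 15000 nM to 100000 nM.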

Compound 4, half-maximal inhibitory concentration: 29700 nM
The estimate for compound 4 lay 1.3-fold (0.13 log units) above the measured number; low and high end bracket the measured number.
By their numbers in this assay, from the lowest: compound 3; then compounds 4, 1 and 2 (each within the scatter of the next).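

In this assay, (2-((tert-butoxycarbonyl)amino)ethyl)amino in place of hydroxy on a carbonyl carbon gives a 1.7-fold lower number from compound 2 to compound 4 (0.22 log units; within the scatter), the only step shown between compounds that differ in one place. At this carbonyl carbon, then, hydroxy can give way to a much larger group, with no ring and no net charge, without a change that stands clear of the scatter. Nothing measured here bears on why the step has this size.

The compounds shown leave open whether a free primary amine in place of the tert-butoxycarbonyl-protected amine, or a longer chain on the same carbonyl carbon, would move the number beyond the scatter. They also leave open what the group on the ring nitrogen contributes alone, since compound 3 differs from the others in more than one place.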